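Isoquinoline ether in place of the dichloropyridazine ether

This account rests on a few compounds, and the source may have more. Where it says the series, first, only, none or still open, it means among the compounds named here.

Measured so far:
compound 1, `CC(C)[C@H](NC(=O)COc1cccc2ccccc12)C(=O)N[C@@H](CC(=O)O)C(=O)CSc1nnnn1-c1ccccc1`: 153000 nM
compound 2, `CC(C)[C@H](NC(=O)COc1cccc2ccccc12)C(=O)N[C@@H](CC(=O)O)C(=O)COc1nncc(Cl)c1Cl`: > 200000 nM

In a functional assay on Jurkat cells (Homo sapiens) for inhibition (a higher number here means a weaker inhibitor, a lower number a stronger inhibitor), compound 1 gives 153000 nM. For compound 2 this assay reports only a limit, > 200000 nM, so compound 2 stands at the limit of > 200000 nM in this assay, at which 1 of the 2 values shown sits, and no number is known for it. Going by the values given here, the one measured step, an at least 1.3-fold higher number from compound 1 to compound 2 (0.11 log units; that floor lies within the scatter), is therefore also only a floor.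

Compound 3, `CC(C)[C@H](NC(=O)COc1cccc2ccccc12)C(=O)N[C@@H](CC(=O)O)C(=O)COc1nccc2ccccc12`, differs from compound 2 by isoquinolin-1-yl in place of 4,5-dichloropyridazin-3-yl on an oxygen on a saturated carbon. No measured step covers this change; the single step shown is small and bounded by a limit, so no direction beyond the scatter can be read from it. Compound 3 is expected to remain weak, with the step of an at least 1.3-fold lower number from compound 2 to compound 3 (0.12 log units; that floor lies within the scatter) as the estimate. For compound 3 the expected value is 150000 nM, within 40000 nM to 600000 nM.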

Compound 3, half-maximal inhibitory concentration: 106000 nM
For compound 3 the middle estimate is 1.4-fold (0.15 log units) above the measured one; the range from low to high includes it.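

In this assay, (isoquinolin-1-yl)oxy gives a measured number at the position where (4,5-dichloropyridazin-3-yl)oxy gave none, with the step reading an at least 1.8-fold lower number from compound 2 to compound 3 (0.27 log units; that floor lies within the scatter). Compound 2 remains a limit, so that step is only a floor: the limit of > 200000 nM in this assay, at which 1 of the 3 values shown sits. Set against (1-phenyl-1H-tetrazol-5-yl)sulfanyl, the change reads a 1.4-fold lower number from compound 1 to compound 3 (0.16 log units; within the scatter), so these two groups are not told apart on this saturated chain carbon.

As far as these compounds go, whether any group here can move the value beyond the scatter remains open. A plain phenoxy group or an amine at this carbon would test that.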